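The source may report more compounds than this note shows. Statements on the series, on what has been measured and on what is new or still open speak of the compounds shown alone.

Working notes on the series. In a functional assay on A549 cells (Homo sapiens) for cytotoxicity, read by MTT assay, with a stated time of 24 h (on this read-out higher numbers stand for weaker inhibition and lower numbers for stronger inhibition), compound 1 `C=CC1=C(C(=O)Nc2ccc(C)cc2)C(c2ccc(F)cc2)OC1` returns only a limit, > 100000 nM. Compound 2 `C=CC1=C(C(=O)Nc2ccccc2)C(c2ccc(F)cc2)OC1` also sits at a limit in this assay, namely > 100000 nM. The step that the two limits leave unreadable from compound 1 to compound 2 therefore cannot be sized. Compound 2 thus stands at the limit shared by every value recorded so far, consistent with the limit of > 100000 nM in this assay, at which 2 of the 2 values shown sit; no number for it exists. Compound 3 `C=CC1=C(C(=O)Nc2ccc(OCC)cc2)C(c2ccc(F)cc2)OC1` differs from compound 2 by ethoxy in place of hydrogen on an aromatic carbon. Among the measured compounds shown here, only one measured step exists, that from compound 1 to compound 2, and it is unreadable; no measured step involves an ethoxy group. The expectation in this assay therefore rests on the two limits alone, and the step that the limit leaves unreadable from compound 2 to compound 3 is expected to leave compound 3 at the limit as well, with no shift beyond the scatter that could be foreseen. Compound 3 is accordingly estimated at 150000 nM, within a range of 30000 nM to 600000 nM, and most likely reported as a limit only.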

Compound 3, half-maximal inhibitory concentration: "not active" (no number reported)
The entry for compound 3 holds no number, and the estimate cannot be compared.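

Compound 3 is entered as not active without a number, so no step from compound 2 to compound 3 can be read, and the other two entries remain limits: the limit of > 100000 nM in this assay, at which 2 of the 3 values shown sit.

The compounds shown leave open whether any substituent at this place on the shared core gives a measurable cytotoxic value.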